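The compounds below may be only part of what the source reports. "The series", "measured", "known", "first", "only" and "open" are said of these compounds alone.

Compound 3 `O=C(Nc1ccc(O)cc1)C1CCc2ccccc2N1` carries a hydroxy group on the outer aromatic ring of the shared core. In a functional assay on PC-3 cells (Homo sapiens) for cytotoxicity, read by sulforhodamine B assay, with a stated time of 72 h (a higher number here means a weaker inhibitor of growth, a lower number a stronger inhibitor of growth), compound 3 gives only a limit of the assay, > 100000 nM, and no number. Two relatives with a trifluoromethyl group instead are measured: compound 1 `O=C(Nc1ccc(C(F)(F)F)cc1)C1CCc2ccccc2N1` gives 20300 nM and compound 2 `O=C(Nc1ccccc1C(F)(F)F)C1CCc2ccccc2N1` gives 53300 nM. Within the data shown here, the change an at least 4.9-fold higher number from compound 1 to compound 3 (0.69 log units; beyond the scatter) is the only measured step that touches this position, and it reaches the limit (the limit of > 100000 nM in this assay, at which 1 of the 3 values shown sits). Compound 4 `COc1ccc(NC(=O)C2CCc3ccccc3N2)cc1` differs from compound 3 by methyl in place of hydrogen on an oxygen on an aromatic ring, that is, hydroxy becomes methoxy. Among the measured compounds shown here, no measured pair shows this exact change, so the expected step of an at least 1.6-fold lower number from compound 3 to compound 4 (0.22 log units; that floor lies within the scatter) is a guess drawn from compound 1 and compound 3. Compound 4 is therefore estimated at 60000 nM, within a range from 15000 nM to 250000 nM.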

Compound 4, concentration for 50% growth inhibition: 56900 nM
Compound 4: the middle estimate sits 1.1-fold (0.02 log units) above what was measured; the range from low to high includes it.
By their numbers in this assay, from the lowest: compound 1; then compounds 2 and 4 (each within the scatter of the next). At a limit, above all of these: compound 3.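

Turning the hydroxy into methoxy gives a measured number for an oxygen group at this position: in this assay the change reads as an at least 1.7-fold lower number from compound 3 to compound 4 (0.24 log units; that floor lies within the scatter) and is known only as a floor. From the compounds shown here alone, its true size stays unknown: the limit of > 100000 nM in this assay, at which 1 of the 4 values shown sits. Methoxy still does not match trifluoromethyl, as a 2.8-fold higher number from compound 1 to compound 4 (0.45 log units; beyond the scatter) shows for the same place on the ring.

Going by these compounds, whether an amine or a carboxylic acid here would lie nearer compound 1 or compound 4 stays open. So does the effect of a longer chain on the oxygen, such as ethoxy.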